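Notes on the aryl step from compound 3 to compound 4

The source may report more compounds than this note shows. Statements on the series, on what has been measured and on what is new or still open speak of the compounds shown alone.

Compound 1 `CNC(=O)c1cc(Oc2ccc(C3=NNC(c4ccc(C#N)cc4)C3)cc2)ccn1` gives 15000 nM in a functional assay on HepG2 cells (Homo sapiens) for cytotoxicity, read by MTT assay, with a stated time of 72 h; a higher number here means a weaker inhibitor, a lower number a stronger inhibitor
Compound 2 `CNC(=O)c1cc(Oc2ccc(C3=NNC(c4ccc(F)cc4Cl)C3)cc2)ccn1` gives 11500 nM
Compound 3 `CNC(=O)c1cc(Oc2ccc(C3=NNC(c4ccccc4)C3)cc2)ccn1` gives 1500 nM

Compound 3 has the lowest of these three numbers, clear of both others. Compound 4 `CNC(=O)c1cc(Oc2ccc(C3=NNC(c4ccc(Cl)c(Cl)c4)C3)cc2)ccn1` differs from it by 3,4-dichlorophenyl in place of phenyl on a saturated ring carbon with 3,4-dichlorophenyl in place of phenyl on a saturated ring carbon. Two modest measured steps bear on this: a 10-fold lower number from compound 1 to compound 3 (1.00 log units; beyond the scatter) and a 7.7-fold lower number from compound 2 to compound 3 (0.88 log units; beyond the scatter) both end at the plain phenyl. The closer precedent is compound 2, whose ring also carries chlorine, and a 1.3-fold lower number from compound 1 to compound 2 (0.12 log units; within the scatter) separates the two substituted rings. Within the data shown here, only three compounds support this, and none goes against it. A modest rise is therefore expected, with an estimated 5.3-fold higher number from compound 3 to compound 4 (0.73 log units; beyond the scatter) in this assay as the step. Compound 4 is estimated at 8000 nM with an expected range from 2500 nM to 20000 nM.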

Compound 4, half-maximal inhibitory concentration: 14400 nM
Compound 4: middle estimate off by 1.8-fold (0.26 log units), on the low side; the measured number falls inside the stated range.
By their numbers in this assay, from the lowest: compound 3; then compounds 2, 4 and 1 (each within the scatter of the next).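

In this assay the step of a 9.6-fold higher number from compound 3 to compound 4 (0.98 log units; beyond the scatter) shows that 3,4-dichlorophenyl also loses the low number of the plain phenyl, so all three substituted rings shown stand beyond the scatter from it. The steps of a 1.3-fold higher number from compound 2 to compound 4 (0.10 log units; within the scatter) and a 1.0-fold lower number from compound 1 to compound 4 (0.02 log units; within the scatter) stay within the scatter, so 3,4-dichlorophenyl cannot be told apart from the other two substituted rings here. No measurement at hand explains this rise.

Still open, going by these compounds, is whether any substituent on this phenyl can match or improve on compound 3. A methoxy group, an amine or a carboxylic acid on this ring would test that.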